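Cytotoxicity notes: ethyl in place of the acyl group

This account rests on a few compounds, and the source may have more. Where it says the series, first, only, none or still open, it means among the compounds named here.

Measured in a functional assay on KB cells (Homo sapiens) for cytotoxicity; a higher number here means a weaker inhibitor, a lower number a stronger inhibitor:
compound 1 `C/C=C/C(=O)OC1=CC(=O)c2ccccc2C1=O` gives 64200 nM
compound 2 `O=C(OC1=CC(=O)c2ccccc2C1=O)c1ccccc1` gives 36900 nM
compound 3 `C=CCOc1ccc2c(c1)C(=O)C=CC2=O` gives 10200 nM

Compound 1 sits level with compound 2 within the scatter, while compound 3 lies beyond the scatter on the lower side of compound 1. The next compound is compound 4 `CCOC1=CC(=O)c2ccccc2C1=O`, with the change (ethyl in place of (prop-1-en-1-yl)carbonyl on an oxygen on an unsaturated carbon). In words, this is ethyl in place of (prop-1-en-1-yl)carbonyl on an oxygen on an unsaturated carbon.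

Going by the values given here, the only measured step, a 1.7-fold lower number from compound 1 to compound 2 (0.24 log units; within the scatter), keeps the carbonyl, so it bears on this change only indirectly. Among the compounds with values here, no measured step removes the carbonyl. Compound 3 at 10200 nM also lacks a carbonyl on its oxygen, but it differs from compound 1 in more than one place and offers only a loose guide. A modest move in this assay toward a lower number is therefore expected, and the expected step is a 2.3-fold lower number from compound 1 to compound 4 (0.36 log units; beyond the scatter) with wide uncertainty. Compound 4 is estimated at 28000 nM, with an expected range from 9000 nM to 70000 nM as its bounds.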

Compound 4, half-maximal inhibitory concentration: 16900 nM
Beside the measured number, compound 4's estimate is 1.7-fold (0.22 log units) above it; measured number inside the range.
By their numbers in this assay, from the lowest: compounds 3 and 4 (each within the scatter of the next); then compounds 2 and 1 (each within the scatter of the next).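

In this assay, the step with ethyl in place of (prop-1-en-1-yl)carbonyl on this oxygen is a 3.8-fold lower number from compound 1 to compound 4 (0.58 log units; beyond the scatter) and lies beyond the scatter, whereas the exchange of one acyl group for another, a 1.7-fold lower number from compound 1 to compound 2 (0.24 log units; within the scatter), stays within it. The carbonyl on this oxygen is therefore not required for cytotoxicity in this small set, and a simple ethyl ether gives a lower number than the crotonate-type acyl group of compound 1. Nothing measured here accounts for this step.

As far as these compounds go, whether the lower number comes from losing the carbonyl or from ethyl itself remains open. Also open, from the compounds shown here alone, is how a longer chain such as butyl, or a chain ending in an amine, would read on this oxygen in this assay, and whether the step would hold on other acyl groups.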